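A Single Methyl Added to Compound 1

A few compounds are considered here, and "the series" means these few. Any claim that something is new, unique, unknown or untested is made for them only; others in the source may bear on it.

Compound 1 `CC(C)C(NC(=O)NO)C(=O)NC1CCCCC1` was tested in a functional assay on MCF7 cells (Homo sapiens) for inhibition; on this read-out higher numbers stand for weaker inhibition and lower numbers for stronger inhibition. In this setting compound 1 gives > 100000 nM, which is a limit of the assay rather than a measured number. For the measured compounds named here, the only other measured compound, compound 2 `CCC(C)C1NC(=O)N(C2CCCCC2)C1=O`, in this assay gives 94300 nM; it has no single-site relation to compound 1, and its value stands on its own. Both results sit at the weak end of the scale, and one of the two falls at the limit (the limit of > 100000 nM in this assay, at which 1 of the 2 values shown sits).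

Compound 3 `CCC(C)C(NC(=O)NO)C(=O)NC1CCCCC1` has not yet been measured. It differs from compound 1 by methyl in place of hydrogen on a saturated chain carbon, three bonds along the chain from an amide-type nitrogen and a carbonyl carbon. Going by the values given here, no pair of measured compounds shows the effect of such a change, and there is no measured step to lean on. With compound 1 already at the limit, a small methyl is expected to leave inhibition weak, with any step of a number no higher from compound 1 to compound 3 (the limit leaves the size open) probably staying within the scatter. Compound 3 is therefore estimated at 100000 nM, within a range from 30000 nM to 300000 nM.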

Compound 3, half-maximal inhibitory concentration: > 100000 nM
Compound 3: a limit, no number; the forecaster's own chance of this, stated with the estimate: 60%; the middle value sits exactly at the limit.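

In this assay compound 1 and compound 3 both end at a limit of the assay rather than at a number, so no step can be read from one to the other: the limit of > 100000 nM in this assay, at which 2 of the 3 values shown sit.

The compounds shown leave open whether methyl in place of hydrogen at this place changes inhibition at all, and if so, by how much.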